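The source may report more compounds than this note shows. Statements on the series, on what has been measured and on what is new or still open speak of the compounds shown alone.

Measured compounds:
- compound 1, `O=C1CC(c2nc(-c3cccc(Cl)c3)no2)CN1Cc1ccc(F)cc1`, in an in vitro functional assay on HEK293-A cells for negative allosteric modulation of metabotropic glutamate receptor 5 (Homo sapiens), read by FLIPR and calcium flux (a higher number here means a weaker inhibitor, a lower number a stronger inhibitor), compound 1 gives 3600 nM
- compound 2, `CC(C)CN1CC(c2nc(-c3cccc(Cl)c3)no2)CC1=O`; compound 2 gives 920 nM
- compound 3, `O=C1CC(c2nc(-c3cccc(Cl)c3)no2)CN1c1cccc(Cl)c1`; compound 3 gives 1100 nM

Compound 3 stands second highest of the three numbers. Its nearest neighbour is compound 2, the step of a 1.2-fold higher number from compound 2 to compound 3 (0.08 log units; within the scatter) lying within the scatter; the furthest is compound 1, with a 3.3-fold lower number from compound 1 to compound 3 (0.51 log units; beyond the scatter).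

Compound 4 is `COc1cccc(N2CC(c3nc(-c4cccc(Cl)c4)no3)CC2=O)c1`. It differs from compound 3 by methoxy in place of chloro on an aromatic carbon. Going by the values given here, no measured step bears directly on this change: the three steps seen so far, a 3.9-fold lower number from compound 1 to compound 2 (0.59 log units; beyond the scatter), a 3.3-fold lower number from compound 1 to compound 3 (0.51 log units; beyond the scatter) and a 1.2-fold higher number from compound 2 to compound 3 (0.08 log units; within the scatter), all swap the whole group on the amide-type nitrogen rather than a substituent on its aromatic ring. The two aryl-bearing and alkyl-bearing compounds 2 and 3 sit within the scatter of each other, which suggests the group on this nitrogen is tolerant of variation. The step of no change at the digits printed from compound 3 to compound 4 (within the scatter) is therefore expected to stay within the scatter, with no preferred direction. Compound 4 is estimated at 1100 nM, with a range of 450 nM to 2700 nM.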

Compound 4, half-maximal inhibitory concentration: 690 nM
Compound 4: the middle estimate sits 1.6-fold (0.20 log units) above what was measured; the measured number falls inside the stated range.
By their numbers in this assay, from the lowest: compounds 4, 2 and 3 (each within the scatter of the next); then compound 1.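

In this assay, going by these compounds alone, the first change on the aromatic ring itself, 3-methoxyphenyl for 3-chlorophenyl, gives a 1.6-fold lower number from compound 3 to compound 4 (0.20 log units; within the scatter) and so does not separate methoxy from chloro at this ring carbon. A second aryl group also stays level with the alkyl group (a 1.3-fold lower number from compound 2 to compound 4 (0.12 log units; within the scatter)), whereas the 4-fluorobenzyl group stands apart (a 5.2-fold lower number from compound 1 to compound 4 (0.72 log units; beyond the scatter)), so among these four compounds only the 4-fluorobenzyl compound departs from the rest. Nothing available explains why these groups read alike at this position.

Going by these compounds, whether this tolerance extends to an amine or a carboxylic acid at the same ring carbon remains open, as does the reading of an unsubstituted phenyl group. These compounds also cannot show whether the gap seen with 4-fluorobenzyl belongs to the fluoro group or to the benzyl group itself.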